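Chloro for Fluoro: Expected Clearance of Compound 3

The source may report more compounds than this note shows. Statements on the series, on what has been measured and on what is new or still open speak of the compounds shown alone.

Compound 1 `O=C(CCSc1nc2cc(F)ccc2o1)N1CCS(=O)(=O)CC1` was tested in an ADME assay on microsomes from liver (Homo sapiens) for metabolic stability, read by LC-MS, using NADPH, with a stated time of 45 min, tested at 0.5 uM (on this read-out higher numbers stand for fast clearance and lower numbers for slow clearance), and gives 0.4 mL/min/g. Compound 2 `CN(C(=O)CCSc1nc2cc(F)ccc2o1)C1CCS(=O)(=O)CC1` is a related compound; in this assay compound 2 returns < 0.4 mL/min/g, which is a limit of the assay rather than a number. Among the measured compounds shown here, compound 1 therefore stands at the only numeric reading so far, and that reading sits at the same figure as the limit of < 0.4 mL/min/g in this assay, at which 1 of the 2 values shown sits. Compound 3 `O=C(CCSc1nc2cc(Cl)ccc2o1)N1CCS(=O)(=O)CC1` has not yet been measured. It differs from compound 1 in one place: chloro in place of fluoro on an aromatic carbon. For the measured compounds named here, no measured pair in this set shares that change, so there is no measured step to lean on. The step of a 1.3-fold higher number from compound 1 to compound 3 (0.10 log units; within the scatter) is expected to be none beyond the usual scatter, or at most a slight rise. Compound 3 is therefore estimated at 0.5 mL/min/g, within a range from 0.25 mL/min/g to 1.2 mL/min/g.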

Compound 3, intrinsic clearance in a liver preparation (reported as CLH), per the amount of preparation that the assay uses: 0.4 mL/min/g
Beside the measured number, compound 3's estimate is 1.3-fold (0.10 log units) above it; the range from low to high includes it.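

In this assay, chloro in place of fluoro on this aromatic carbon gives no change at the digits printed from compound 1 to compound 3 (within the scatter). The earlier compounds shown here both carried fluoro, so they could not show whether this place responds to the choice of halogen; here, the two halogens read alike. A drop from compound 1 would be hard to see, however, because this figure is also where the assay stops giving numbers: the limit of < 0.4 mL/min/g in this assay, at which 1 of the 3 values shown sits.

The compounds shown leave open whether a plain hydrogen, a methoxy group or an amine at this place would read alike, since all three compounds carry a halogen there. Among the compounds shown here, they also leave open whether chloro would read the same on the other amide, the one in compound 2, and only a compound with faster clearance would show how much this place can matter.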